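The source may hold more compounds than are shown below. What is called first, only, known or untested is meant among the compounds shown, and "the series" means these compounds.

Going by the values given here, in a physicochemical assay for solubility, at pH 7.4 (on this read-out higher numbers stand for higher solubility and lower numbers for lower solubility), compound 1 `CC[C@H]1[C@@H](N)CN1c1c(F)cc2c(=O)c(C(=O)O)cn(C3CC3)c2c1F` gives 55.9 ug/mL, the higher of the two numbers so far, while compound 2 `C[C@H]1N(c2cc3c(cc2F)c(=O)c(C(=O)O)cn3C2CC2)C[C@]1(C)N` gives 1.3 ug/mL, a gap well beyond the scatter. Compound 3 `CN(C)C1CN(c2c(F)cc3c(=O)c(C(=O)O)cn(C4CC4)c3c2F)C1` keeps the core of compound 1 and swaps one group on an aromatic carbon: a group of 7 heavy atoms (5 carbon, 2 nitrogen; one four-membered non-aromatic ring with 1 hetero atom) in place of a group of 7 heavy atoms (5 carbon, 2 nitrogen; one four-membered non-aromatic ring with 1 hetero atom), on an aromatic carbon. Among the compounds with values here, the two measured compounds differ in more than one place, so they offer no step to borrow and any forecast stays rough. The expected step in this assay is a moderate fall, a 1.9-fold lower number from compound 1 to compound 3 (0.27 log units; within the scatter). For compound 3 the estimate is 30 ug/mL, with an expected range from 8 ug/mL to 110 ug/mL.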

Compound 3, solubility: 58 ug/mL
The estimate for compound 3 lay 1.9-fold (0.29 log units) below the measured number; the range from low to high includes it.
By their numbers in this assay, from the lowest: compound 2; then compounds 1 and 3 (each within the scatter of the next).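

In this assay, the move to 3-(dimethylamino)azetidin-1-yl on this aromatic carbon gives a 1.0-fold higher number from compound 1 to compound 3 (0.02 log units; within the scatter) and so leaves the number unchanged within the scatter. At this position, the same atoms can thus be joined differently, with the hydrogen-bond donor and both defined stereocentres of the leaving group gone, and no change can be read. Nothing available explains this result. Still open, going by these compounds, is whether the number would hold with a different group here, such as 3-hydroxyazetidin-1-yl or pyrrolidin-1-yl.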